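Stretching the Allyl Arm of Compound 1

A few compounds are considered here, and "the series" means these few. Any claim that something is new, unique, unknown or untested is made for them only; others in the source may bear on it.

Measured so far:
compound 1 `C=CCC(O)(c1ccc(OC)c(OC)c1OC)c1cccc2ccccc12` in a functional assay on MDA-MB-231 cells (Homo sapiens) for inhibition, read by sulforhodamine B assay, with a stated time of 48 h; a lower number here means a stronger inhibitor, a higher number a weaker inhibitor: > 20000 nM
compound 2 `CCOC(=O)/C=C/CO/N=C(/c1ccc(OC)c(OC)c1OC)c1cccc2ccccc12`: > 20000 nM

In this assay compound 1 gives only the limit > 20000 nM, which is a limit of the assay and not a number. Compound 2 likewise gives the limit > 20000 nM. Within the data shown here, both results sit at the limit of > 20000 nM in this assay, at which 2 of the 2 values shown sit, so compound 1 stands level with the only other compound and no ranking is possible. Compound 3 `COc1ccc(C(O)(C/C=C\c2ccccc2)c2cccc3ccccc23)c(OC)c1OC` differs from compound 1 by 2-phenylethenyl in place of vinyl on a saturated chain carbon, two bonds along the chain from two aromatic carbons and an oxygen on a saturated carbon. Among the measured compounds shown here, no measured step shows what such a change does, so the expected step that the limit leaves unreadable from compound 1 to compound 3 is none beyond the scatter, with a strong chance that only a limit is reported again. Compound 3 is therefore estimated at 25000 nM, between 8000 nM and 80000 nM.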

Compound 3, half-maximal inhibitory concentration: 12800 nM
For compound 3 the middle estimate is 2.0-fold (0.29 log units) above the measured one, and the stated range covers the measured number.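

In this assay, 2-phenylethenyl in place of vinyl at this position gives an at least 1.5-fold lower number from compound 1 to compound 3 (0.19 log units; that floor lies within the scatter). Among these compounds, compound 3 is the first compound here to give a number rather than a limit, so this saturated chain carbon can carry an added aromatic ring without activity being lost. The true size of the step stays unknown because compound 1 gives only a limit: the limit of > 20000 nM in this assay, at which 2 of the 3 values shown sit.

From the compounds shown here alone, whether an amine on the new phenyl ring would lower the number further remains open. So does the effect of a longer chain between the phenyl ring and the core.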